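The source may report more compounds than this note shows. Statements on the series, on what has been measured and on what is new or still open speak of the compounds shown alone.

Series in a toxicity assay on HT-29 cells (Homo sapiens) for cytotoxicity; on this read-out higher numbers stand for lower toxicity in this test and lower numbers for higher toxicity in this test:
- compound 1 `CC(C)CCn1nc(C(=O)N[C@H]2COc3ccccc3N(C)C2=S)nc1Cc1ccccc1`: > 100000 nM, a limit
- compound 2 `CN1C(=S)[C@@H](NC(=O)c2nc(Cc3ccccc3)n(C3CCCCCC3)n2)COc2ccccc21`: > 100000 nM, a limit
- compound 3 `CN1C(=S)[C@@H](NC(=O)c2nc(Cc3ccccc3)n(C3CCOC3)n2)COc2ccccc21`: > 100000 nM, a limit

Compound 3 has no number, only this limit, and it shares it with the other two compounds: the limit of > 100000 nM in this assay, at which 3 of the 3 values shown sit.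

The next structure is compound 4 `CN1C(=S)[C@@H](NC(=O)c2nc(Cc3ccccc3)n(CC3COC3)n2)COc2ccccc21`, which has (oxetan-3-yl)methyl in place of oxolan-3-yl on an aromatic nitrogen. The two have the same atoms, joined differently.

Going by the values given here, the steps that bear on this change are those at the same nitrogen: a step that the two limits leave unreadable from compound 1 to compound 3, a step that the two limits leave unreadable from compound 2 to compound 3 and a step that the two limits leave unreadable from compound 1 to compound 2. None of them has a readable size, so none gives a direction. Isopentyl, cycloheptyl and oxolan-3-yl all end at the limit, and no compound in this small set goes against that.

For this assay, the expected step is a number no higher from compound 3 to compound 4 (the limit leaves the size open), with no change expected beyond the scatter. A further limit is the most likely report. The estimate for compound 4 is 100000 nM, within an estimated range of 60000 nM to 150000 nM.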

Compound 4, half-maximal cytotoxic concentration: > 100000 nM
Compound 4: only a limit was reported; the forecaster's own chance of this, stated with the estimate: 90%; the middle value sits exactly at the limit.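

In this assay, going by these compounds alone, compound 4 gives > 100000 nM, a limit, and no step from compound 1, compound 2 or compound 3 to compound 4 can be read: the limit of > 100000 nM in this assay, at which 4 of the 4 values shown sit.

The compounds shown leave open whether any group on this aromatic nitrogen changes the read-out in this assay at all.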